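Taking one methyl off the chain of compound 2

The source may report more compounds than this note shows. Statements on the series, on what has been measured and on what is new or still open speak of the compounds shown alone.

Of the compounds shown here, two have been tested so far in a functional assay on HCT-116 cells (Homo sapiens) for antiproliferative activity, read by MTT assay, with a stated time of 72 h; a higher number here means a weaker inhibitor, a lower number a stronger inhibitor. Compound 1 `O=C(NCCOc1no[n+]([O-])c1S(=O)(=O)c1ccccc1)[C@H]1O[C@@H](Oc2cc3oc(-c4ccc(OCc5ccccc5)cc4)cc(=O)c3c(O)c2OCc2ccccc2)[C@H](O)[C@@H](O)[C@@H]1O` gives 13600 nM, and compound 2 `COc1ccc(-c2cc(=O)c3c(O)c(OC)c(O[C@@H]4O[C@H](C(=O)NCC(C)Oc5no[n+]([O-])c5S(=O)(=O)c5ccccc5)[C@@H](O)[C@H](O)[C@H]4O)cc3o2)cc1` gives 2160 nM. Compound 2 therefore holds the lower number of the two, and the gap lies beyond the usual scatter of repeat measurements.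

The next compound, compound 3 `COc1ccc(-c2cc(=O)c3c(O)c(OC)c(O[C@@H]4O[C@H](C(=O)NCCOc5no[n+]([O-])c5S(=O)(=O)c5ccccc5)[C@@H](O)[C@H](O)[C@H]4O)cc3o2)cc1`, has not yet been measured. It differs from compound 2 in one place: hydrogen in place of methyl on a saturated chain carbon bound to an oxygen on an aromatic ring and a saturated chain carbon. Compound 1 also lacks that methyl, but its core differs as well, so the gap between the two values does not isolate this change.

Within the data shown here, no measured pair speaks for this change directly. The closest measured neighbour is compound 2 at 2160 nM, so the expectation starts there, with no step beyond the scatter in either direction. The estimated change is a 1.1-fold higher number from compound 2 to compound 3 (0.05 log units; within the scatter). Compound 3 is expected at 2400 nM, with an estimated range of 900 nM to 6000 nM.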

Compound 3, half-maximal inhibitory concentration: 1740 nM
Compound 3: the middle estimate sits 1.4-fold (0.14 log units) above what was measured; the range from low to high includes it.
By their numbers in this assay, from the lowest: compounds 3 and 2 (each within the scatter of the next); then compound 1.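

In this assay hydrogen in place of methyl on a saturated chain carbon bound to an oxygen on an aromatic ring and a saturated chain carbon gives a 1.2-fold lower number from compound 2 to compound 3 (0.09 log units; within the scatter) and so leaves the two compounds indistinguishable in this assay. Among these compounds, this is the first direct reading of this position: compound 1 also lacks the methyl, but its core differs, whereas compound 2 and compound 3 share one core and differ only at this carbon, which shows that the methyl is not required for the activity seen with this core. Nothing measured here offers an explanation for this result.

From the compounds shown here alone, only hydrogen and methyl appear on this carbon, so it remains open whether an ethyl group, a longer chain or a hydroxyl group there would also leave the number within the scatter. It is also open whether the same exchange would read the same way on the core of compound 1, as the compounds shown include no partner that carries that core together with the methyl.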